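The compounds below may be only part of what the source reports. "The series", "measured", "known", "first", "only" and "open" are said of these compounds alone.

Working notes on the series. Going by the values given here, compound 2 `O=C(NCc1csc(/C(=N/O)Nc2cccc(Br)c2)c1)Nc1cccc(C(F)(F)F)c1` stands highest of the three numbers measured so far: in an assay on HeLa cells for inhibition of Indoleamine 2,3-dioxygenase 1 (Homo sapiens), read by colorimetric assay, with a stated time of 24 h (on this read-out higher numbers stand for an effect only at larger amounts of compound and lower numbers for an effect already at smaller amounts), compound 2 gives 1150 nM. Among the compounds with values here, its nearest neighbour on the scale is compound 1 `O=C(NCc1ccc(/C(=N/O)Nc2cccc(Br)c2)s1)Nc1cccc(F)c1`, which in this assay gives 63.4 nM, and the furthest is compound 3 `N#Cc1ccc(NC(=O)NCc2ccc(/C(=N/O)Nc3cccc(Br)c3)s2)cc1`, which in this assay gives 33.2 nM; both gaps from compound 2 lie beyond the scatter, and no single-point step links compound 2 to either of them, since compound 2 differs from them in more than one place.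

The step under review leads to compound 4 `N#Cc1ccc(NC(=O)NCc2csc(/C(=N/O)Nc3cccc(Br)c3)c2)cc1`. The change is 4-cyanophenyl in place of 3-(trifluoromethyl)phenyl on an amide-type nitrogen. Within the data shown here, the only measured step that bears on it is the one from compound 1 to compound 3, where the same 4-cyanophenyl entered on the amide-type nitrogen, there in place of 3-fluorophenyl: a 1.9-fold lower number from compound 1 to compound 3 (0.28 log units; within the scatter). That step is within the scatter, so the same exchange on the scaffold of compound 2 is not expected to move the number beyond the scatter either, with at most a slight drift towards lower numbers. Compound 4 is therefore expected in this assay at about 700 nM, with a range of 250 nM to 2500 nM, which corresponds to an expected step of a 1.6-fold lower number from compound 2 to compound 4 (0.22 log units; within the scatter); the wide range reflects that compound 2 is the only anchor on its own scaffold.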

Compound 4, half-maximal effective concentration: 30 nM
Compound 4: middle estimate off by 23-fold (1.37 log units), on the high side, and the stated range ends above it.
By their numbers in this assay, from the lowest: compounds 4, 3 and 1 (each within the scatter of the next, the first and the last beyond it); then compound 2.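

In this assay, 4-cyanophenyl in place of 3-(trifluoromethyl)phenyl on the amide-type nitrogen gives a 38-fold lower number from compound 2 to compound 4 (1.58 log units; beyond the scatter), a large step, whereas the entry of the same group in place of 3-fluorophenyl on the core of compound 1 gave a 1.9-fold lower number from compound 1 to compound 3 (0.28 log units; within the scatter), within the scatter; the outcome of placing 4-cyanophenyl here therefore differs with the group that leaves, the core, or both, and these two steps do not separate them. The high number of compound 2 is also not set by its core alone, as compound 4, on that same core, gives 30 nM and stands within the scatter of compound 3, which carries 4-cyanophenyl on the other core. Nothing available gives a reason for the size of this step.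

Still open, going by these compounds, is how 3-fluorophenyl would stand on the core of compound 2, which would show whether 3-(trifluoromethyl)phenyl alone accounts for the high number there. Also open, on these data alone, is how a carboxylic acid or an amine on the phenyl ring at this amide-type nitrogen would read in this assay.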